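This account rests on a few compounds, and the source may have more. Where it says the series, first, only, none or still open, it means among the compounds named here.

Compound 1 `CN(C(=O)NC(=O)c1cccc(C(F)(F)F)c1)c1nc(C(F)(F)F)c(C(=O)N/N=C/c2cc(C(F)(F)F)cc(C(F)(F)F)c2)s1`: 6.08 ug/mL
Compound 2 `CN(C(=O)NC(=O)c1ccc(C(F)(F)F)cc1)c1nc(C(F)(F)F)c(C(=O)N/N=C/c2cccc(C(F)(F)F)c2)s1`: 8.95 ug/mL

Of the compounds shown here, two have been measured in a functional assay on MCF7 cells (Homo sapiens) for inhibition, read by MTT assay, with a stated time of 72 h; a higher number here means a weaker inhibitor, a lower number a stronger inhibitor. Compound 1 gives 6.08 ug/mL and compound 2 gives 8.95 ug/mL in this assay. Compound 2 and compound 1 therefore lie within the usual scatter of one another, so the two numbers cannot be told apart with confidence.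

Compound 3 `CN(C(=O)NC(=O)c1ccc(C(F)(F)F)cc1)c1nc(C(F)(F)F)c(C(=O)N/N=C/c2cc(C(F)(F)F)cc(C(F)(F)F)c2)s1` has not yet been measured. It differs from compound 2 in one place: trifluoromethyl in place of hydrogen on an aromatic carbon. With this change, compound 3 carries the same hydrazone aryl ring as compound 1, while keeping the acyl urea ring of compound 2. Among the measured compounds shown here, since no step between measured compounds isolates this change, there is no direct guide to its size. For the measured compounds named here, the only available comparison is that compound 1, which has this aryl ring, and compound 2, which lacks it, fall within the scatter of each other. Compound 3 is thus expected to show a step from compound 2 of a 1.3-fold lower number from compound 2 to compound 3 (0.11 log units; within the scatter), that is, no change beyond the scatter. For compound 3 the estimate in this assay is 7 ug/mL, with a range from 3 ug/mL to 16 ug/mL.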

Compound 3, half-maximal inhibitory concentration: 7.37 ug/mL
Estimate against measurement, compound 3: 1.1-fold (0.02 log units) below; the range from low to high includes it.
By their numbers in this assay, from the lowest: compounds 1, 3 and 2 (each within the scatter of the next).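

In this assay, among the compounds shown here, trifluoromethyl in place of hydrogen on an aromatic carbon, meta to a large group and meta to a trifluoromethyl group, gives a 1.2-fold lower number from compound 2 to compound 3 (0.08 log units; within the scatter) and so isolates this change for the first time, showing that this position takes the added group with no difference that can be told from the scatter. Compound 3 also links compound 1 to the series through a single change, 4-(trifluoromethyl)phenyl in place of 3-(trifluoromethyl)phenyl on a carbonyl carbon, and this gives a 1.2-fold higher number from compound 1 to compound 3 (0.08 log units; within the scatter) so that the two placements of trifluoromethyl on that phenyl group cannot be told apart in this series either. No measurement at hand offers an explanation for either step.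

The compounds shown leave open whether this aromatic carbon would accept anything other than hydrogen or trifluoromethyl, such as an amine or a carboxylic acid, since both steps rest on this one group alone. They also leave open whether replacing the trifluoromethyl-bearing phenyl group on the carbonyl carbon with a longer chain would give a step beyond the scatter.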